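From furan-2-yl to 4-methoxyphenyl on the shared core

The source may report more compounds than this note shows. Statements on the series, on what has been measured and on what is new or still open speak of the compounds shown alone.

Compound 1 `COc1ccc(S(=O)(=O)N2CCc3cccc(-c4ccco4)c32)cc1`: 42 nM
Compound 2 `COc1ccc(S(=O)(=O)N2CCc3cccc(-c4cc(OC)c(OC)c(OC)c4)c32)cc1`: 1080 nM

In a functional assay on MKN-45 cells (Homo sapiens) for inhibition, with a stated time of 72 h (a lower number here means a stronger inhibitor, a higher number a weaker inhibitor), compound 1 has the lower of the two measured numbers, and the gap up to compound 2 lies beyond the scatter. Compound 3 `COc1ccc(-c2cccc3c2N(S(=O)(=O)c2ccc(OC)cc2)CC3)cc1` keeps the core of compound 1 but carries 4-methoxyphenyl in place of furan-2-yl on an aromatic carbon. Going by the values given here, no measured pair shows this change on its own, so the data offer no direct step. Among the compounds with values here, the only other guide is compound 2 at 1080 nM, so a rise in the number beyond the scatter, toward a weaker inhibitor, is expected in this assay. The expected change is a step of a 5.2-fold higher number from compound 1 to compound 3 (0.72 log units; beyond the scatter). For compound 3 the estimated value is 220 nM, with an expected range of 60 nM to 800 nM.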

Compound 3, half-maximal inhibitory concentration: 211 nM
Beside the measured number, compound 3's estimate is 1.0-fold (0.02 log units) above it, and the stated range covers the measured number.
By their numbers in this assay, from the lowest: compound 1; then compound 3; then compound 2.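

In this assay, the swap of furan-2-yl for 4-methoxyphenyl on this aromatic carbon now has a direct reading, a 5.0-fold higher number from compound 1 to compound 3 (0.70 log units; beyond the scatter), so the five-membered aromatic ring with one hetero atom gives the lower number of this pair, while the six-membered aromatic ring of carbon only still keeps the number modest. With a single methoxy group on the new ring, compound 3 gives 211 nM, whereas compound 2, with its trimethoxyphenyl group, gives 1080 nM, which places the 4-methoxyphenyl compound between the other two. Nothing measured here accounts for the step.

The compounds shown leave open how an unsubstituted phenyl or a thiophene ring would read at this position. They also do not show whether an amine or a carboxylic acid could be placed on this aromatic carbon.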